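Swapping Chloro for Methoxy on a Sulfonamide Amine

The source may hold more compounds than are shown below. What is called first, only, known or untested is meant among the compounds shown, and "the series" means these compounds.

Three measured compounds share a sulfonamide joined through a chain to a benzylamine. Compound 1 `O=S(=O)(NCCCNCc1ccc(Cl)cc1)c1cc(C(F)(F)F)cc(C(F)(F)F)c1` gives 2800 nM in a functional assay on MIA PaCa-2 cells (Homo sapiens) for inhibition, read by MTT assay, with a stated time of 72 h (on this read-out higher numbers stand for weaker inhibition of growth and lower numbers for stronger inhibition of growth), the lowest number of the three. Compound 3 `O=S(=O)(NCCCCCCNCc1ccc(Br)cc1)c1cc(C(F)(F)F)cc(C(F)(F)F)c1` gives 2970 nM, which lies within the scatter of compound 1, so the two cannot be ranked. Compound 2 `O=S(=O)(NCCCCCCNCc1ccc(Br)cc1)c1ccccc1Cl` gives 13700 nM, a weaker result that sits beyond the scatter from compound 1. Compound 4 `COc1ccc(CNCCCNS(=O)(=O)c2cc(C(F)(F)F)cc(C(F)(F)F)c2)cc1` differs from compound 1 in one place: methoxy in place of chloro on an aromatic carbon. For the measured compounds named here, no measured pair shows this change, so its effect is unknown from these data. A modest step, probably not beyond the scatter, is expected. Compound 4 is expected to give 3500 nM, with an estimated range from 1500 nM to 8000 nM. That estimate corresponds to an expected step of a 1.3-fold higher number from compound 1 to compound 4 (0.10 log units; within the scatter).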

Compound 4, concentration for 50% growth inhibition: 2500 nM
For compound 4 the middle estimate is 1.4-fold (0.15 log units) above the measured one; the range from low to high includes it.
By their numbers in this assay, from the lowest: compounds 4, 1 and 3 (each within the scatter of the next); then compound 2.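

In this assay, methoxy in place of chloro on the benzyl ring gives a 1.1-fold lower number from compound 1 to compound 4 (0.05 log units; within the scatter). For the compounds shown here, this is the first measured step at this position, and it shows that 4-methoxybenzyl, with one more heavy atom and one hydrogen-bond acceptor, can stand in for 4-chlorobenzyl without a change that can be read in this assay. No supporting measurement bears on why the two groups read alike.

Going by these compounds, whether an amine, a carboxylic acid or a nitrile at this place would also read alike stays open. So does whether the same swap behaves this way on a longer chain, such as the one in compound 3.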